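The source may hold more compounds than are shown below. What is called first, only, known or untested is meant among the compounds shown, and "the series" means these compounds.

In an ADME assay on microsomes (Mus musculus) for metabolic stability (on this read-out higher numbers stand for fast clearance and lower numbers for slow clearance), compound 2 (`CNC(=O)[C@@H]1CCCN1S(=O)(=O)c1ccc(Cl)c(COc2cccc3c(-c4nccn4C)cc(C)nc23)c1Cl`) gives 917 mL/min/kg. For the measured compounds named here, the only other measured compound, compound 1 (`CNC(=O)[C@@H]1CCCN1S(=O)(=O)c1ccc(Cl)c(COc2cccc3c(C(F)(F)F)cc(C)nc23)c1Cl`), gives 1380 mL/min/kg, and these two numbers lie within the scatter of each other, so neither can be placed ahead of the other on this read-out.

Compound 3 (`CNC(=O)[C@@H]1CCCN1S(=O)(=O)c1ccc(Cl)c(COc2cccc3c(-c4cccnc4)cc(C)nc23)c1Cl`) keeps the shared core of compound 2 and alters one group: pyridin-3-yl in place of 1-methyl-1H-imidazol-2-yl on an aromatic carbon. In words, pyridin-3-yl stands in place of 1-methyl-1H-imidazol-2-yl on an aromatic carbon, opposite the ring nitrogen. Going by the values given here, one measured step bears on this, made at the same carbon, where 1-methyl-1H-imidazol-2-yl stands in place of trifluoromethyl: a 1.5-fold lower number from compound 1 to compound 2 (0.18 log units; within the scatter). That step stays within the scatter. Among the compounds with values here, no measured compound carries pyridin-3-yl, so the evidence is indirect and rests on this single pair. Within the data shown here, with only that step to go on, no shift beyond the scatter is expected in this assay. The estimated step is a 1.1-fold higher number from compound 2 to compound 3 (0.04 log units; within the scatter), which is too small to give a meaningful direction. For compound 3 the expected value is about 1000 mL/min/kg, with an estimated range of 550 mL/min/kg to 1800 mL/min/kg.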

Compound 3, clearance: 700 mL/min/kg
For compound 3 the middle estimate is 1.4-fold (0.15 log units) above the measured one; the range from low to high includes it.
By their numbers in this assay, from the lowest: compounds 3, 2 and 1 (each within the scatter of the next).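

In this assay, putting a six-membered aromatic ring with 1 hetero atom in place of a five-membered aromatic ring with 2 hetero atoms, at the carbon opposite the ring nitrogen, gives a 1.3-fold lower number from compound 2 to compound 3 (0.12 log units; within the scatter), so pyridin-3-yl and 1-methyl-1H-imidazol-2-yl cannot be told apart on this read-out. Pyridin-3-yl in place of trifluoromethyl gives a 2.0-fold lower number from compound 1 to compound 3 (0.29 log units; within the scatter), and this step, the largest among the three compounds, is still printed as within the scatter. This position has now carried two different aromatic rings as well as trifluoromethyl, and no pair among these three compounds separates beyond the scatter in this assay.

Nothing given here bears on why the three values lie where they do. From the compounds shown here alone, it remains open whether an amine, a carboxylic acid or a longer alkyl chain on this same carbon, or a change at another place on the shared core, would give a step beyond the scatter.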